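The compounds below may be only part of what the source reports. "The series", "measured", "known", "first", "only" and "open" are said of these compounds alone.

Compounds in a functional assay for inhibition, with Homo sapiens as the target; on this read-out lower numbers stand for stronger inhibition and higher numbers for weaker inhibition:
- Compound 1 `COc1cc(OC)c(C(=O)/C=C/c2ccc([N+](=O)[O-])cc2)c(OC)c1`: 407 nM
- Compound 2 `COc1cc(OC)c(C(=O)/C=C/c2ccc(C(=O)O)cc2)c(OC)c1`: 6230 nM
- Compound 3 `COc1cc(OC)c(C(=O)/C=C/c2ccc(C(N)=O)cc2)c(OC)c1`: not yet measured

Of the two measured compounds, compound 2 has the higher number, at 6230 nM. The change to compound 3 is amino in place of hydroxy on a carbonyl carbon, or carboxy to carbamoyl. Going by the values given here, one measured step bears on it, a large one with carboxy in place of nitro on an aromatic carbon: a 15-fold higher number from compound 1 to compound 2 (1.18 log units; beyond the scatter). Among the compounds with values here, no carbamoyl compound has been measured, so the guide is weak. With carboxy leaving, a moderate move to a lower number is expected in this assay, recovering part of that step. The expected step is a 3.5-fold lower number from compound 2 to compound 3 (0.54 log units; beyond the scatter). Compound 3 is estimated at 1800 nM, with an expected range of 500 nM to 6500 nM.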

Compound 3, half-maximal inhibitory concentration: 1790 nM
Estimate against measurement, compound 3: 1.0-fold (0.00 log units) above, within the range that was stated.
By their numbers in this assay, from the lowest: compound 1; then compound 3; then compound 2.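

In this assay, amino in place of hydroxy on a carbonyl carbon changes one heavy atom and still gives a step beyond the scatter, a 3.5-fold lower number from compound 2 to compound 3 (0.54 log units; beyond the scatter), so this position responds to a small change within the carbonyl group. Carbamoyl recovers only part of the earlier loss, with a 4.4-fold higher number from compound 1 to compound 3 (0.64 log units; beyond the scatter), leaving nitro with the lowest number of the three groups. No available data explain either step.

On these data alone, it remains open whether a nitrile or a methyl ester would come closer to nitro, and whether this order holds on another core.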